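This account rests on a few compounds, and the source may have more. Where it says the series, first, only, none or still open, it means among the compounds named here.

Two close analogues of one shared core have been measured in an assay on cells for displacement of a labelled ligand from adenosine receptor A1 (Homo sapiens), with a stated time of 60 min, tested at 1 uM; a lower number here means less inhibition, a higher number more inhibition at the concentration tested (going by the name of the read-out). Compound 1, `CCOC(=O)C1=C(C)N/C(=N\C#N)NC1c1ccsc1`, carries a thiophen-3-yl group on a saturated ring carbon, and in this assay compound 1 gives 29%. Compound 2, `CCOC(=O)C1=C(C)N/C(=N\C#N)NC1c1ccccc1`, carries a phenyl group in the same place, and in this assay compound 2 gives 18%. Among the compounds with values here, the single measured step, a number 11 percentage points lower from compound 1 to compound 2 (beyond the scatter), is therefore a modest drop that lies beyond the usual scatter, and compound 2 stands as the lower of the two numbers, with compound 1 as its only neighbour.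

Compound 3, `CCOC(=O)C1=C(C)N/C(=N\C#N)NC1C1CCCC1`, has not yet been measured. It differs from compound 2 in one place: cyclopentyl in place of phenyl on a saturated ring carbon. Within the data shown here, no measured step swaps an aromatic ring for a saturated one; the only step known, from compound 1 to compound 2, swaps one aromatic ring for another and is modest in size. On that slim basis a step of about no change at the digits printed from compound 2 to compound 3 (within the scatter) is expected, which is within the scatter, so compound 3 is estimated at 18%, with a plausible range from 4% to 34%.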

Compound 3, a percentage reported as inhibition, at one concentration (the size of the read-out at that concentration, not a potency): 11%
For compound 3 the middle estimate is 7 percentage points above the measured one; the measured number falls inside the stated range.
By their numbers in this assay, from the lowest: compounds 3 and 2 (each within the scatter of the next); then compound 1.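

In this assay, the change from an aromatic ring to a saturated one at this carbon gives a number 7 percentage points lower from compound 2 to compound 3 (within the scatter), so among these compounds cyclopentyl cannot be told apart from phenyl, and an aromatic ring does not appear to be required to keep the number in the range seen with phenyl. The other comparison, a number 18 percentage points lower from compound 1 to compound 3 (beyond the scatter), is a modest step beyond the scatter, which means that thiophen-3-yl is separated from both rings made of carbon only, though three compounds are too few to call this a general pattern. Nothing available here accounts for why thiophen-3-yl stands apart from the other two rings.

The compounds shown leave open whether an open chain such as butyl, or a ring carrying an amine or a carboxylic acid, would move the number further in either direction at this position. Since each number is the size of the read-out at a single concentration, they also leave open how potency differs across the three compounds.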